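Adding a Single Chlorine to the Bare Phenyl Urea

The source may report more compounds than this note shows. Statements on the series, on what has been measured and on what is new or still open speak of the compounds shown alone.

Three close analogues built on one shared core have been tested in an assay on isolated protein for inhibition of Polyunsaturated fatty acid 5-lipoxygenase (Homo sapiens), read by HPLC, with a stated time of 10 min; on this read-out higher numbers stand for weaker inhibition and lower numbers for stronger inhibition. Compound 1 `Cc1cc(OCc2nc3ccccc3s2)ccc1NC(=O)Nc1ccc(Cl)c(Cl)c1` gives 230 nM in this assay. Compound 2 `Cc1cc(OCc2nc3ccccc3s2)ccc1NC(=O)Nc1ccccc1Cl` gives 830 nM. Compound 3 `Cc1cc(NC(=O)Nc2ccccc2)ccc1OCc1nc2ccccc2s1`, which carries a plain phenyl on the urea, gives 2070 nM, the highest of the three numbers; compound 2 lies nearest to it and compound 1 furthest, and both gaps exceed the usual scatter of repeated measurements.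

Compound 4 `Cc1cc(NC(=O)Nc2cccc(Cl)c2)ccc1OCc1nc2ccccc2s1` has not yet been measured. It differs from compound 3 by chloro in place of hydrogen on an aromatic carbon. Among the compounds with values here, one measured step bears on this change: a 3.6-fold higher number from compound 1 to compound 2 (0.56 log units; beyond the scatter), in which a ring carrying two chlorines was swapped for a ring with a single chlorine in another position, and the number rose. Compound 1 and compound 3 are not linked by a single-change step, but their two values show that the ring with two chlorines gives a much lower number than the bare ring.

Adding one chlorine is therefore expected to lower the number for compound 4 by a modest amount, a 2.6-fold lower number from compound 3 to compound 4 (0.41 log units; beyond the scatter), in this assay. Compound 4 is expected to give 800 nM, within a range from 300 nM to 2000 nM.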

Compound 4, half-maximal inhibitory concentration: 2090 nM
Estimate against measurement, compound 4: 2.6-fold (0.42 log units) below, and the stated range ends below it.
By their numbers in this assay, from the lowest: compound 1; then compound 2; then compounds 3 and 4 (each within the scatter of the next).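

In this assay, chloro in place of hydrogen on an aromatic carbon, meta to a large group, gives a 1.0-fold higher number from compound 3 to compound 4 (0.00 log units; within the scatter), so within the scatter this single chlorine leaves the number where the plain phenyl had it. Within the data shown here, this is the first direct look at one chlorine on this ring of the urea, and it shows that the chlorine at this position does not by itself bring the number down; compounds 1 and 2 differ from compound 4 in more than one place, so their lower numbers say nothing direct about this change. No measurement shown here explains why the chlorine makes no difference at this position.

Still open, from the compounds shown here alone, is whether a different group on the same carbon, such as a methoxy group, an amine or a carboxylic acid, would shift the number where chloro does not. Also open, going by these compounds, is whether, on the core of compound 4, a 3,4-dichlorophenyl ring would give a lower number than the 3-chlorophenyl ring does.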